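Dropping the Sulfonyl: From Compound 2 to Compound 4

The compounds below may be only part of what the source reports. "The series", "measured", "known", "first", "only" and "open" are said of these compounds alone.

Three compounds share one core, an aromatic ring carrying two trifluoromethyl groups, and differ only in the third substituent. Compound 1 `C=CC(=O)Nc1cc(C(F)(F)F)cc(C(F)(F)F)c1` carries a (vinylcarbonyl)amino group, and in an ADME assay for pharmacokinetics, read by LC-MS, in phosphate buffer, with a stated time of 72 h, at pH 7.4, tested at 250 uM (a higher number here means that the compound lasts longer, a lower number that the compound disappears faster), compound 1 gives 6.1 h. Compound 2 `C=CS(=O)(=O)c1cc(C(F)(F)F)cc(C(F)(F)F)c1` carries a vinylsulfonyl group instead. In this assay compound 2 gives only a limit, < 0.017 h, so its true number is not known. Compound 3 `O=C1C=CC(=O)N1c1cc(C(F)(F)F)cc(C(F)(F)F)c1` carries a five-membered ring group, and in this assay compound 3 also reaches only a limit, < 0.017 h. Thus an at least 350-fold lower number from compound 1 to compound 2 (2.55 log units; beyond the scatter), and an at least 350-fold lower number from compound 1 to compound 3 (2.55 log units; beyond the scatter), while a step that the two limits leave unreadable from compound 2 to compound 3. Compound 2 therefore stands at the floor of what this assay can report, a place it shares with compound 3 (the limit of < 0.017 h in this assay, at which 2 of the 3 values shown sit).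

Compound 4 `C=Cc1cc(C(F)(F)F)cc(C(F)(F)F)c1` is the next step: vinyl in place of vinylsulfonyl on an aromatic carbon. Among the measured compounds shown here, no measured step removes the vinylsulfonyl in this way. For the measured compounds named here, the only step that touches it, an at least 350-fold lower number from compound 1 to compound 2 (2.55 log units; beyond the scatter), shows that putting vinylsulfonyl in place of (vinylcarbonyl)amino lowered the number by a large amount, so taking vinylsulfonyl away is expected to move the number back up, and from a limit any measured value is an increase. Compound 4 is expected to give 100 h, between 10 h and 1000 h, which is expected to mean an at least 5800-fold higher number from compound 2 to compound 4 (3.76 log units; beyond the scatter).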

Compound 4, half-life: > 50 h
Compound 4: no number, only a limit; the forecaster's own chance of this, stated with the estimate: 60%; the middle value lies beyond the limit too.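

Replacing vinylsulfonyl with vinyl on this aromatic carbon gives an at least 2900-fold higher number from compound 2 to compound 4 (3.46 log units; beyond the scatter), and putting vinyl in place of the five-membered ring group gives a step of similar reach, an at least 2900-fold higher number from compound 3 to compound 4 (3.46 log units; beyond the scatter). Vinyl also compares well with the group in the only earlier compound that lasted for hours, with an at least 8.1-fold higher number from compound 1 to compound 4 (0.91 log units; beyond the scatter), so compound 4 lasts longest of the four in this assay, and a vinyl group on the shared core is clearly compatible with long survival in this buffer. The result for compound 4 is a limit rather than a number, and it marks the opposite end of what the assay can report from the limits of compound 2 and compound 3: the limit of > 50 h in this assay, at which 1 of the 4 values shown sits.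

Going by these compounds, the true half-life of compound 4 remains unknown, so all three steps give only minimum sizes, and the limits shared by compound 2 and compound 3 still leave the step between them unreadable. These compounds also leave open how a saturated ethyl chain or an amine on the same aromatic carbon would behave, and so whether the double bond of the vinyl group matters at all for how long compound 4 lasts.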